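Cyclohexyl in place of butyl in compound 2

The source may report more compounds than this note shows. Statements on the series, on what has been measured and on what is new or still open speak of the compounds shown alone.

Compound 1 (`CC(C)(C)CCOc1cccc(O)c1C(=O)/C=C/c1ccc(C(=O)O)cc1`) gives 11200 nM in a functional assay on MDA-MB-231 cells (Homo sapiens) for antiproliferative activity, read by sulforhodamine B assay; a higher number here means a weaker inhibitor of growth, a lower number a stronger inhibitor of growth
Compound 2 (`CCCCCCOc1cccc(O)c1C(=O)/C=C/c1ccc(O)cc1`) gives > 30000 nM in this assay
Compound 3 (`O=C(/C=C/c1ccc(O)cc1)c1c(O)cccc1OCCC1CCCCC1`) has not yet been measured

Compound 2 has no exact number, and > 30000 nM is a limit of the assay. Compound 3 keeps the core of compound 2 and changes only one chain (cyclohexyl in place of butyl on a saturated chain carbon, two bonds along the chain from an oxygen on an aromatic ring). Cyclohexyl stands in place of butyl on a saturated chain carbon, two bonds along the chain from an oxygen on an aromatic ring, so hexyloxy becomes 2-cyclohexylethoxy.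

Going by the values given here, no pair of measured compounds shows a change of this kind, so there is no direct guide to its size. Among the compounds with values here, compound 1 gives 11200 nM as the only exact number here, but it differs from compound 3 in more than this one chain. The expected outcome is therefore little or no change in this assay, with no clear direction and nothing beyond the usual scatter. The estimate is a small step, an at least 1.0-fold lower number from compound 2 to compound 3 (0.02 log units; that floor lies within the scatter), and a reading that again reaches the limit would be no surprise. In this assay compound 3 is estimated at 28000 nM, with an expected range from 12000 nM to 60000 nM overall.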

Compound 3, concentration for 50% growth inhibition: > 30000 nM
Compound 3: no number, only a limit; the forecaster's own chance of this, stated with the estimate: 50%; middle value at least 1.0-fold (0.02 log units) away from the limit.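

The change from compound 2 to compound 3 cannot be sized, because both readings stop at a limit of the assay rather than at a number: the limit of > 30000 nM in this assay, at which 2 of the 3 values shown sit. The compounds shown leave open whether cyclohexyl in place of butyl on this chain alters growth inhibition at all, and in which direction.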